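The source may report more compounds than this note shows. Statements on the series, on what has been measured and on what is new or still open speak of the compounds shown alone.

Compound 1 `COc1cc(C(c2ccc(O)c(OC)c2)[C@@H](C)[C@@H](C)CF)ccc1O` is the starting point of this comparison. In a functional assay on HL-60 cells (Homo sapiens) for cytotoxicity, read by WST assay, with a stated time of 48 h (on this read-out lower numbers stand for stronger inhibition and higher numbers for weaker inhibition), compound 1 gives 38000 nM, the highest of the two numbers reported, while compound 2 `COc1cc(C(c2ccc(O)c(OC)c2)[C@@H](C)C(C)C)ccc1O` gives 20000 nM; the step of a 1.9-fold lower number from compound 1 to compound 2 (0.28 log units; within the scatter) lies within the scatter. Compound 3 `COc1cc(C(c2ccc(O)c(OC)c2)[C@H](CO)C(C)C)ccc1O` is reported in this assay only as a limit, > 100000 nM. The steps of an at least 2.6-fold higher number from compound 1 to compound 3 (0.42 log units; beyond the scatter) and an at least 5.0-fold higher number from compound 2 to compound 3 (0.69 log units; beyond the scatter) both lie beyond the scatter, toward weaker inhibition.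

Compound 4 `COC[C@@H](C)[C@H](C)C(c1ccc(O)c(OC)c1)c1ccc(O)c(OC)c1` differs from compound 1 by 1-(methoxymethyl)ethyl in place of 1-(fluoromethyl)ethyl on a saturated chain carbon bound to two saturated chain carbons. The nearest measured step is a 1.9-fold lower number from compound 1 to compound 2 (0.28 log units; within the scatter), which removes the fluoro without a change beyond the scatter. The two steps to compound 3 show that 1-(hydroxymethyl)-2-methylpropyl entering raises the number, but compound 4 brings a 2-(methoxymethyl)-1-methylpropyl instead, so those steps bear only loosely on it. Compound 4 is expected to change little, estimated at 40000 nM in this assay, with a range of 15000 nM to 100000 nM. The expected step is a 1.1-fold higher number from compound 1 to compound 4 (0.02 log units; within the scatter), within the scatter.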

Compound 4, half-maximal inhibitory concentration: 73000 nM
Compound 4: middle estimate off by 1.8-fold (0.26 log units), on the low side, and the stated range covers the measured number.
By their numbers in this assay, from the lowest: compounds 2, 1 and 4 (each within the scatter of the next, the first and the last beyond it). At a limit, above all of these: compound 3.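

In this assay, 1-(methoxymethyl)ethyl in place of 1-(fluoromethyl)ethyl, on a saturated chain carbon bound to two saturated chain carbons, gives a 1.9-fold higher number from compound 1 to compound 4 (0.28 log units; within the scatter), a step within the scatter, so this pair does not separate methoxy from fluoro. Set against hydrogen, however, methoxy gives a 3.7-fold higher number from compound 2 to compound 4 (0.56 log units; beyond the scatter), while fluoro gives a 1.9-fold lower number from compound 1 to compound 2 (0.28 log units; within the scatter); only the methoxy step clears the scatter, with compound 1 lying within the scatter of both others. As far as these compounds go, with 2-(methoxymethyl)-1-methylpropyl in place of 1-(hydroxymethyl)-2-methylpropyl, on a saturated chain carbon bound to two aromatic carbons, the step is an at least 1.3-fold lower number from compound 3 to compound 4 (0.13 log units; that floor lies within the scatter), and that floor lies within the scatter, so the full size of this step stays open. Compound 3 stands only at a limit: the limit of > 100000 nM in this assay, at which 1 of the 4 values shown sits.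

The compounds shown leave open how a free hydroxyl, an amine or a carboxylic acid would read at this chain end. They also leave open whether a longer ether, such as ethoxy, would continue the rise seen with methoxy.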